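A few compounds are considered here, and "the series" means these few. Any claim that something is new, unique, unknown or untested is made for them only; others in the source may bear on it.

Compound 1 `CNC(=O)CC1CCc2cc(OC)c(OC)cc21` and compound 2 `COc1cc2c(cc1OC)C(CC(=O)NC1CCCC1)CC2` share one core and differ only in the group on the amide-type nitrogen. In a functional assay on the whole organism (strain Wistar) for inhibition, with Rattus norvegicus as the target, read by paw edema, with stated times of 60 min and 2 h, at a dose of 100 mg/kg by the oral route (a lower number here means less inhibition, a higher number more inhibition at the dose given (going by the name of the read-out)), compound 1 gives 30%, and compound 2 gives 52%. Putting cyclopentyl in place of methyl on that nitrogen gave a number 22 percentage points higher from compound 1 to compound 2 (beyond the scatter), so compound 2 stands highest of the two measured compounds, with compound 1 the nearest number and clearly beyond the scatter below it. Compound 3 `COc1cc2c(cc1OC)C(CC(=O)N1CCCC1)CC2` has not yet been measured. It differs from compound 2 in one place: pyrrolidin-1-yl in place of cyclopentylamino on a carbonyl carbon. The group that leaves carries the amide hydrogen; the group that enters carries none. Within the data shown here, only one measured step exists, and it concerns the size of the group on the nitrogen, not the exchange of an amino group for a ring nitrogen, so nothing measured bears directly on this change. In this assay compound 3 is therefore expected to land near compound 2, with a step estimated at a number 7 percentage points lower from compound 2 to compound 3 (within the scatter). There is no measured basis for a larger move in either direction. The estimate for compound 3 is 45%, in a range from 25% to 65%.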

Compound 3, a percentage reported as inhibition, in the whole organism at one dose (the size of the read-out at that dose, not a potency): 20%
For compound 3 the middle estimate is 25 percentage points above the measured one; measured number outside the range, below it.
By their numbers in this assay, from the lowest: compounds 3 and 1 (each within the scatter of the next); then compound 2.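

In this assay, pyrrolidin-1-yl in place of cyclopentylamino on the carbonyl carbon gives a number 32 percentage points lower from compound 2 to compound 3 (beyond the scatter), even though both groups carry a five-membered ring, so this position distinguishes between two groups that look much alike on paper. The other listed step, a number 10 percentage points lower from compound 1 to compound 3 (within the scatter), shows that among these three compounds a ring on this carbonyl carbon does not by itself go with the higher number: the ring of compound 3 gives no separation from the small methylamino group of compound 1, whereas the cyclopentylamino group of compound 2 does. The leaving group carries the amide hydrogen and the entering group does not, but no measurement here shows what lies behind the drop.

The compounds shown leave open whether the amide hydrogen or the way the ring is attached matters more, a question that cyclopentyl(methyl)amino on the same carbonyl carbon would help to separate. They also leave open how ring size plays out on either type of nitrogen, for example with cyclohexylamino or piperidin-1-yl.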